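This account rests on a few compounds, and the source may have more. Where it says the series, first, only, none or still open, it means among the compounds named here.

Measured in a physicochemical assay for solubility, in phosphate buffer, measured as kinetic solubility, at pH 7.4; on this read-out higher numbers stand for higher solubility and lower numbers for lower solubility:
- Compound 1 `Cc1ccccc1-c1nc(CN2CCC(C(=O)NCCCN3CCC(C)(C)CC3)CC2)c(C)o1`: > 69 ug/mL
- Compound 2 `Cc1oc(-c2c(Cl)cccc2Cl)nc1CN1CCC(C(=O)NCCCN2C[C@H](C)C[C@H](C)C2)CC1`: > 77 ug/mL

Compound 1 reads > 69 ug/mL, which is a limit of the assay and not a number. Compound 2 reads > 77 ug/mL, which is also a limit and not a number. Neither compound has an exact reading, so the two cannot be placed in order.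

Compound 3 `COc1cccc(Br)c1-c1nc(CN2CCC(C(=O)NCCCN3C[C@H](C)C[C@H](C)C3)CC2)c(C)o1` has not yet been measured. It differs from compound 2 in one place, an aromatic carbon of a five-membered aromatic ring with 1 nitrogen and 1 oxygen, where 2-bromo-6-methoxyphenyl stands in place of 2,6-dichlorophenyl (2-bromo-6-methoxyphenyl in place of 2,6-dichlorophenyl on an aromatic carbon).

Within the data shown here, no two measured compounds differ in just one place, so the data give no direct size for such a change. The expectation therefore leans on compound 2, with its limit of > 77 ug/mL. The expected step, a step that the limit leaves unreadable from compound 2 to compound 3, is estimated to stay within the usual scatter, with no clear direction. Another limit would be no surprise. For compound 3 the estimated value is 80 ug/mL, with an expected range from 45 ug/mL to 90 ug/mL.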

Compound 3, solubility: > 83 ug/mL
Compound 3: only a limit was reported (the forecaster's own chance of this, stated with the estimate: 70%); middle value at least 1.0-fold (0.01 log units) from the limit.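

In this assay compound 2 reads > 77 ug/mL, which is a limit and not a number. Compound 3 reads > 83 ug/mL, which is also a limit, and the step from 2,6-dichlorophenyl to 2-bromo-6-methoxyphenyl cannot be read. The compounds shown leave open where the true values lie in this assay, and whether this change shifts them at all.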